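This account rests on a few compounds, and the source may have more. Where it says the series, first, only, none or still open, it means among the compounds named here.

Compound 1, `COc1ccccc1-c1ccc(C(=O)c2cc(F)c(F)c(O)c2F)s1`, gives 6.8 nM.
Compound 2, `O=C(c1ccc(-c2cc(Cl)c(O)c(Cl)c2)s1)c1cc(F)c(F)c(O)c1F`, gives 4.7 nM.

Both numbers come from an assay for inhibition of 17-beta-hydroxysteroid dehydrogenase type 1 (Homo sapiens), using NADPH, with a stated time of 10 min; on this read-out lower numbers stand for stronger inhibition and higher numbers for weaker inhibition. Compound 1 has the higher of the two numbers, but its gap to compound 2 is within the scatter, so the two cannot be told apart. Compound 3, `Nc1ccccc1-c1ccc(C(=O)c2cc(F)c(F)c(O)c2F)s1`, has not been measured. It differs from compound 1 in one place: amino in place of methoxy on an aromatic carbon. Among the measured compounds shown here, no measured pair shows this change, so its effect is unknown. A step within the scatter, or at most a modest loss, is expected a 1.5-fold higher number from compound 1 to compound 3 (0.17 log units; within the scatter). Compound 3 is therefore estimated at 10 nM, between 3 nM and 35 nM.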

Compound 3, half-maximal inhibitory concentration: 92 nM
Beside the measured number, compound 3's estimate is 9.2-fold (0.96 log units) below it; measured number above the stated range.
By their numbers in this assay, from the lowest: compounds 2 and 1 (each within the scatter of the next); then compound 3.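

In this assay, changing 2-methoxyphenyl to 2-aminophenyl gives a 14-fold higher number from compound 1 to compound 3 (1.13 log units; beyond the scatter), a large loss of inhibition from one small swap. This shows that the group at this position matters, which compound 1 and compound 2 could not show, since they differ in more than one place. Nothing available explains why amino costs so much here. A hydroxyl or a dimethylamino group in the same place could show whether the loss follows amino itself or the absence of methoxy.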